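The source may report more compounds than this note shows. Statements on the series, on what has been measured and on what is new or still open speak of the compounds shown alone.

Working notes on the series. Of the compounds shown here, three sharing one core have been measured in an assay for inhibition of Fatty-acid amide hydrolase 1 (Rattus norvegicus); a lower number here means a stronger inhibitor, a higher number a weaker inhibitor. Compound 1 `CNC(=O)c1cnc(C(=O)CCc2ccc(COc3ccccc3)cc2)o1` gives 3.6 nM in this assay. Compound 2 `COC(=O)c1ccc(-c2cnc(C(=O)CCc3ccc(COc4ccccc4)cc3)o2)nc1` gives 3.5 nM. Compound 3 `COC(=O)c1ccc(-c2cnc(C(=O)CCc3ccc(Oc4ccccc4)cc3)o2)nc1` gives 54 nM, the highest number of the three. The cores of compound 2 and compound 3 differ by phenoxy in place of phenoxymethyl on an aromatic carbon; that step is a 15-fold higher number from compound 2 to compound 3 (1.19 log units; beyond the scatter). Compound 4 `CNC(=O)c1cnc(C(=O)CCc2ccc(Oc3ccccc3)cc2)o1` has not yet been measured in this assay.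

The change from compound 2 to compound 1 is methylcarbamoyl in place of 5-(methoxycarbonyl)pyridin-2-yl on an aromatic carbon, and it made a step of a 1.0-fold higher number from compound 2 to compound 1 (0.01 log units; within the scatter). The change from compound 3 to compound 4 is methylcarbamoyl in place of 5-(methoxycarbonyl)pyridin-2-yl on an aromatic carbon. The place is described in the same words for both pairs, so this is the same change; among the compounds here it occurs two times, once measured and once open. Because the earlier step of a 1.0-fold higher number from compound 2 to compound 1 (0.01 log units; within the scatter) lay within the scatter, the expected step in this assay is a 1.0-fold higher number from compound 3 to compound 4 (0.01 log units; within the scatter), staying close to compound 3. Compound 4 is accordingly estimated at 55 nM, with a range from 20 nM to 150 nM, in this assay.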

Compound 4, inhibition constant: 11 nM
The estimate for compound 4 lay 5.0-fold (0.70 log units) above the measured number, outside the stated range (below it).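

In this assay, methylcarbamoyl in place of 5-(methoxycarbonyl)pyridin-2-yl gave a 4.9-fold lower number from compound 3 to compound 4 (0.69 log units; beyond the scatter), so this change does not carry over unaltered from the core bearing phenoxymethyl to the core bearing phenoxy: the same change on two cores in this assay, a 1.0-fold higher number (0.01 log units; within the scatter) from compound 2 to compound 1 and a 4.9-fold lower number (0.69 log units; beyond the scatter) from compound 3 to compound 4, 5.0-fold (0.70 log units) apart, beyond the scatter of two such steps. Seen from the other side, phenoxy in place of phenoxymethyl gave a 3.1-fold higher number from compound 1 to compound 4 (0.49 log units; beyond the scatter), a higher number on both pairs but not a step of the same size: the same change on two cores in this assay, a 15-fold higher number (1.19 log units; beyond the scatter) from compound 2 to compound 3 and a 3.1-fold higher number (0.49 log units; beyond the scatter) from compound 1 to compound 4, 5.0-fold (0.70 log units) apart, beyond the scatter of two such steps. The effects of the two changes are therefore not additive across these four compounds, but this single set of four does not show what underlies that, or how either change would behave on any further core.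

The compounds shown leave open how other groups on the aromatic carbon next to the ring oxygen would behave, such as a dimethylcarbamoyl group or a pyridine bearing a carboxylic acid in place of the methyl ester. Also open, from the compounds shown here alone, is whether a longer chain, such as phenoxyethyl, would follow the same dependence on the core.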